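Swapping the oxanyl group for a pyrazolyl ring

The source may hold more compounds than are shown below. What is called first, only, known or untested is meant among the compounds shown, and "the series" means these compounds.

Measured compounds:
compound 1 `COCc1ccc(-c2ccc3nnc(C(N)=O)c(N[C@@H](C)c4nn(C)cc4C)c3c2)cn1` — 44 nM
compound 2 `C[C@H](Nc1c(C(N)=O)nnc2ccc(-c3ccc(OCCCN4CCCC4)nc3)cc12)C1CCOCC1` — 1.8 nM

In an assay on HT-29 cells for inhibition of Serine-protein kinase ATM (Homo sapiens), read by fluorescence, with a stated time of 1 h (on this read-out lower numbers stand for stronger inhibition and higher numbers for weaker inhibition), compound 2 gives 1.8 nM, the lowest of the two numbers, while compound 1 gives 44 nM; that gap is beyond the scatter. Compound 1 and compound 2 differ in two places at once, so the two values alone do not show which place carries the difference.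

Compound 3 `Cc1cn(C)nc1[C@H](C)Nc1c(C(N)=O)nnc2ccc(-c3ccc(OCCCN4CCCC4)nc3)cc12` keeps the core and the pyridine side of compound 2 and changes only the amine side: 1,4-dimethyl-1H-pyrazol-3-yl in place of oxan-4-yl on a saturated chain carbon bound to a nitrogen on an aromatic ring and a saturated chain carbon. For the measured compounds named here, no single step between measured compounds covers this exchange, so there is no measured guide for its size. The expectation is a small step, if any, with compound 3 slightly weaker than compound 2, as expressed by a 1.9-fold higher number from compound 2 to compound 3 (0.29 log units; within the scatter). Compound 3 is therefore estimated at 3.5 nM, with a plausible range from 1 nM to 12 nM.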

Compound 3, half-maximal inhibitory concentration in the Serine-protein kinase ATM assay: 0.5 nM
Compound 3: middle estimate off by 7.0-fold (0.85 log units), on the high side; measured number below the stated range.
By their numbers in the Serine-protein kinase ATM assay, from the lowest: compound 3; then compound 2; then compound 1.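

In the Serine-protein kinase ATM assay, the amine side now has a step of its own: with the 3-(pyrrolidin-1-yl)propoxy group held fixed, 1,4-dimethyl-1H-pyrazol-3-yl in place of oxan-4-yl leads from compound 2 at 1.8 nM to compound 3 at 0.5 nM, which is a 3.6-fold lower number from compound 2 to compound 3 (0.56 log units; beyond the scatter), so this position matters on its own. In the Serine-protein kinase ATM assay, with the pyrazolyl group held fixed, 3-(pyrrolidin-1-yl)propoxy in place of methoxymethyl gives an 88-fold lower number from compound 1 to compound 3 (1.94 log units; beyond the scatter), a much larger step, so most of the gap between compound 1 and compound 3 lies in this other place. In a physicochemical assay for lipophilicity, using the shake flask method, measured as octanol-water partition, with a stated time of 30 min, at pH 7.4 (on this read-out lower numbers stand for lower lipophilicity and higher numbers for higher lipophilicity), compound 2 gives 1.9 and compound 3 gives 2.1; the exchange of oxan-4-yl for the pyrazolyl group gives a number 0.20 log units higher from compound 2 to compound 3 (within the scatter), and nothing measured here explains either potency step.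

On these data alone, it remains open whether the pyrazolyl gain would also appear with methoxymethyl in the other place. A phenyl or cyclohexyl ring on the same saturated chain carbon is also untested among the compounds shown.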